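Methoxy for methyl on the compound 2 scaffold

The compounds below may be only part of what the source reports. "The series", "measured", "known", "first", "only" and "open" are said of these compounds alone.

For the measured compounds named here, in a functional assay on MCF7 cells (Homo sapiens) for cytotoxicity, read by CellTiter-Glo, with a stated time of 5 days (a lower number here means a stronger inhibitor, a higher number a weaker inhibitor), compound 1 (`CC/C(=C(/c1ccc(/C=C/C(=O)O)cc1)c1ccc2[nH]ncc2c1)c1ccccc1`) gives 6 nM and compound 2 (`CC/C(=C(/c1ccc(/C=C/C(=O)O)c(C)c1)c1ccc2[nH]ncc2c1)c1ccccc1`) gives 14 nM as the higher of the two numbers so far. The change to compound 3 (`CC/C(=C(/c1ccc(/C=C/C(=O)O)c(OC)c1)c1ccc2[nH]ncc2c1)c1ccccc1`) is methoxy in place of methyl on an aromatic carbon with methoxy in place of methyl on an aromatic carbon, ortho to a 2-carboxyethenyl group and meta to a large group. Going by the values given here, one measured step bears on this carbon: a 2.3-fold higher number from compound 1 to compound 2 (0.37 log units; beyond the scatter) for methyl in place of hydrogen, a modest step. Among the compounds with values here, no measured compound carries methoxy, so the direction of any shift is unknown. Going from one group to another on the same carbon, a step no larger than that one is expected. The estimate is a 1.1-fold lower number from compound 2 to compound 3 (0.03 log units; within the scatter) in this assay as the expected outcome. Compound 3 is estimated at 13 nM with an expected range of 5 nM to 35 nM for the measurement.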

Compound 3, half-maximal inhibitory concentration: 31 nM
Estimate against measurement, compound 3: 2.4-fold (0.38 log units) below, within the range that was stated.
By their numbers in this assay, from the lowest: compound 1; then compound 2; then compound 3.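

On the aromatic carbon ortho to a 2-carboxyethenyl group, this assay separates methoxy from methyl (a 2.2-fold higher number from compound 2 to compound 3 (0.35 log units; beyond the scatter)), so replacing one substituent with the other at this position is not neutral. Against hydrogen, the methoxy change gives a larger step (a 5.2-fold higher number from compound 1 to compound 3 (0.71 log units; beyond the scatter)), and with a 2.3-fold higher number from compound 1 to compound 2 (0.37 log units; beyond the scatter) the three compounds shown rank hydrogen, then methyl, then methoxy from the lowest number, with no compound here going against that order. No supporting data accompany these values to account for the shift.

Going by these compounds, whether a fluorine, a hydroxyl or an amine on this carbon would stay near compound 1 or follow the rise seen with methyl and methoxy remains open. Also open, on these data alone, is whether a longer chain such as ethoxy would extend the same trend.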